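The compounds below may be only part of what the source reports. "The series", "measured", "known", "first", "only" and "open" are said of these compounds alone.

In a physicochemical assay for lipophilicity, measured as octanol-water partition (a lower number here means a more polar compound, a higher number a more lipophilic compound), compound 1 (`N#Cc1c(-c2ccco2)[n+]([O-])c2ccc(F)cc2[n+]1[O-]`) gives 0.983 and compound 2 (`Cc1ccc(-c2c(C#N)[n+]([O-])c3ccccc3[n+]2[O-])cc1`) gives 2.09 which is the higher of the two numbers and lies beyond the scatter from compound 1. Compound 3 (`Cc1ccc(-c2c(C#N)[n+]([O-])c3cc(F)ccc3[n+]2[O-])cc1`) differs from compound 2 by one change (fluoro in place of hydrogen on an aromatic carbon) with fluoro in place of hydrogen on an aromatic carbon. Among the compounds with values here, no measured pair shows this change on its own. A small rise is expected in this assay with the estimated step (a number 0.11 log units higher from compound 2 to compound 3 (within the scatter)) not clearly beyond the scatter. For compound 3 the estimated value is 2.2 with an expected range of 1.85 to 2.55 in this series.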

Compound 3, partition coefficient: 2.48
Beside the measured number, compound 3's estimate is 0.28 log units below it, and the stated range covers the measured number.
By their numbers in this assay, from the lowest: compound 1; then compound 2; then compound 3.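

In this assay, fluoro in place of hydrogen on an aromatic carbon of the fused system now has its own measured step, a number 0.39 log units higher from compound 2 to compound 3 (beyond the scatter) and modest in size. Within the data shown here, this is the first reading of the change on its own, and it lies beyond the scatter. The other single-place change, 4-methylphenyl in place of furan-2-yl on an aromatic carbon, gives a number 1.50 log units higher from compound 1 to compound 3 (beyond the scatter) and is large. No measurement on hand bears on why either number moves. Still open, as far as these compounds go, is whether an amine or a carboxylic acid in place of that fluoro would shift the number the same way.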